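Moving the Methyl Around the Benzyl Ring

The source may report more compounds than this note shows. Statements on the series, on what has been measured and on what is new or still open speak of the compounds shown alone.

Three esters sharing one core have been measured in an assay on isolated protein for inhibition of protein kinase C zeta type (Homo sapiens), with stated times of 1 h and 2.5 min, tested at 30 uM; on this read-out lower numbers stand for less inhibition and higher numbers for more inhibition at the one concentration tested (going by the name of the read-out). Compound 1 `COc1ccc(-c2csc(N)c2C(=O)Oc2ccccc2)cc1OC` gives 48% in this assay. Compound 2 `COc1ccc(-c2csc(N)c2C(=O)OCc2ccccc2)cc1OC` gives 100%, and compound 3 `COc1ccc(-c2csc(N)c2C(=O)OCc2ccccc2C)cc1OC` gives 64%. Compound 3 stands second highest of the three: its nearest neighbour is compound 1, and the step of a number 16 percentage points higher from compound 1 to compound 3 (beyond the scatter) lies beyond the scatter, while the step of a number 36 percentage points lower from compound 2 to compound 3 (beyond the scatter) is large and sets compound 3 well apart from the highest value.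

Compound 4 `COc1ccc(-c2csc(N)c2C(=O)OCc2cccc(C)c2)cc1OC` differs from compound 3 only in the methyl: 3-methylphenyl in place of 2-methylphenyl on a saturated chain carbon bound to an oxygen next to a carbonyl group. Among the measured compounds shown here, no measured step shifts a methyl from one aromatic carbon to another, so the only guides are that placing a methyl on the benzyl ring cost a number 36 percentage points lower from compound 2 to compound 3 (beyond the scatter), whereas the benzyl ester gained a number 52 percentage points higher from compound 1 to compound 2 (beyond the scatter) over the phenyl ester. Compound 4 is expected to lie above compound 3 without reaching compound 2. For compound 4 the expected step is a number 11 percentage points higher from compound 3 to compound 4 (beyond the scatter), which may not exceed the scatter. Compound 4 is estimated at 75%, within 50% to 100%.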

Compound 4, a percentage reported as inhibition, at one concentration (the size of the read-out at that concentration, not a potency): 67%
Beside the measured number, compound 4's estimate is 8 percentage points above it; measured number inside the range.
By their numbers in this assay, from the lowest: compound 1; then compounds 3 and 4 (each within the scatter of the next); then compound 2.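

In this assay, 3-methylphenyl in place of 2-methylphenyl on a saturated chain carbon bound to an oxygen next to a carbonyl group gives a number 3 percentage points higher from compound 3 to compound 4 (within the scatter) and so the two methyl placements cannot be told apart on this read-out. The drop from the unsubstituted benzyl ester is therefore not tied to the 2-methylbenzyl alone, since the 3-methylbenzyl ester shows a number 33 percentage points lower from compound 2 to compound 4 (beyond the scatter) as well. That ester still holds a number 19 percentage points higher from compound 1 to compound 4 (beyond the scatter) over the phenyl ester, so both methylated benzyl esters remain separated from the phenyl ester.

Still open, as far as these compounds go, is whether a methoxy group or a chlorine atom in place of this methyl would behave like it, and whether a longer chain such as a phenethyl ester would hold the level of compound 2. Nothing measured here explains these differences.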